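Hydroxy Addition Across Two Cores of the Lactone Series

A few compounds are considered here, and "the series" means these few. Any claim that something is new, unique, unknown or untested is made for them only; others in the source may bear on it.

Compound 1 `CCCCOc1cccc(C[C@H]2C(=O)OC[C@@H]2Cc2ccccc2)c1` is taken as the reference for the first core. In a functional assay on HL-60 cells (Homo sapiens) for cytotoxicity, read by WST assay, with a stated time of 48 h (on this read-out higher numbers stand for an effect only at larger amounts of compound and lower numbers for an effect already at smaller amounts), compound 1 gives 26000 nM. Among the measured compounds shown here, compound 2 `CCCCOc1cc(C[C@H]2C(=O)OC[C@@H]2Cc2ccccc2)ccc1O` carries the change hydroxy in place of hydrogen on an aromatic carbon and in this assay compound 2 gives 35000 nM; the step of a 1.3-fold higher number from compound 1 to compound 2 (0.13 log units; within the scatter) is the only measured instance of this change.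

Compound 3 `O=C1OC[C@H](Cc2ccccc2)[C@H]1Cc1ccc(Cl)c(Cl)c1` belongs to a second core; the difference between the two cores is not broken down here. In this assay compound 3 gives 19000 nM, and the gaps of compound 3 to compound 1 and to compound 2 both stay within the scatter.

Compound 4 `O=C1OC[C@H](Cc2ccccc2O)[C@H]1Cc1ccc(Cl)c(Cl)c1` is not yet measured. It carries hydroxy in place of hydrogen on an aromatic carbon, the same kind of change as in compound 2, but the place differs: in compound 2 the hydroxy sits ortho to a butoxy group and para to a large group, whereas in compound 4 it sits ortho to a large group. The expectation for the step of a 1.3-fold higher number from compound 3 to compound 4 (0.10 log units; within the scatter) rests on the measured step of a 1.3-fold higher number from compound 1 to compound 2 (0.13 log units; within the scatter) being within the scatter. Compound 4 is therefore estimated at 24000 nM in this assay, within 12000 nM to 50000 nM.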

Compound 4, half-maximal effective concentration: 33000 nM
The estimate for compound 4 lay 1.4-fold (0.14 log units) below the measured number, and the stated range covers the measured number.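

In this assay, hydroxy in place of hydrogen on an aromatic carbon gives a 1.7-fold higher number from compound 3 to compound 4 (0.24 log units; within the scatter). Set beside the earlier step, the change shows no detectable difference between the two cores: the same change on two cores in this assay, a 1.3-fold higher number (0.13 log units; within the scatter) from compound 1 to compound 2 and a 1.7-fold higher number (0.24 log units; within the scatter) from compound 3 to compound 4, 1.3-fold (0.11 log units) apart, within the scatter of two such steps This shows only that the change leaves the number within the scatter on both cores; it does not show that hydroxy has no effect, and two pairs cannot exclude a dependence on the core that is smaller than the scatter, while the hydroxy also stands in a different place in each pair, so core and place remain unseparated.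

The compounds shown leave open whether hydroxy gives a comparable step when it sits ortho to a large group on the core of compound 1. They also leave open whether an amine, a carboxylic acid or a methoxy group in that place would stay within the scatter on either core.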